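This account rests on a few compounds, and the source may have more. Where it says the series, first, only, none or still open, it means among the compounds named here.

In an assay on cells for inhibition of MAP kinase-interacting serine/threonine-protein kinase 1 (Homo sapiens), read by mobility shift assay, with stated times of 10 min and 60 min, in the presence of a further agent that is not named here (a lower number here means a stronger inhibitor, a higher number a weaker inhibitor), three compounds of one core have been measured. Compound 1 `NC(=O)c1ccc(-c2cccnc2)cc1OC1CCNCC1` gives 1100 nM. Compound 2 `Cc1cc(-c2cccnc2)ccc1C(N)=O` gives 22000 nM. Compound 3 `NC(=O)c1ccc(-c2cccnc2)cc1OC1CCC1` gives 1900 nM. Among these three numbers compound 3 stands second highest: its nearest neighbour is compound 1, from which it is separated by a 1.7-fold higher number from compound 1 to compound 3 (0.24 log units; within the scatter), a gap within the scatter, and its furthest is compound 2, separated by a 12-fold lower number from compound 2 to compound 3 (1.06 log units; beyond the scatter), a gap beyond the scatter.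

Compound 4 `NC(=O)c1ccc(-c2cccnc2)cc1Cl` differs from compound 3 in one place: chloro in place of cyclobutyloxy on an aromatic carbon.

Going by the values given here, two measured steps bear on this change. Going from the piperidinyloxy of compound 1 to the methyl of compound 2 brought a 20-fold higher number from compound 1 to compound 2 (1.30 log units; beyond the scatter), and going from the methyl of compound 2 to the cyclobutyloxy of compound 3 brought a 12-fold lower number from compound 2 to compound 3 (1.06 log units; beyond the scatter). Both show that exchanging a group bearing an ether oxygen for a single small substituent on this aromatic carbon is accompanied by a large rise in this assay. Chloro, like methyl, is one atom without a ring or an acceptor, so compound 4 is expected to behave more like compound 2 than like compound 3, and the step of a 5.3-fold higher number from compound 3 to compound 4 (0.72 log units; beyond the scatter) is estimated to be large and upward. Compound 4 is therefore expected to give about 10000 nM, with a plausible range from 3000 nM to 30000 nM.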

Compound 4, half-maximal inhibitory concentration: 11000 nM
The estimate for compound 4 lay 1.1-fold (0.04 log units) below the measured number; the range from low to high includes it.
By their numbers in this assay, from the lowest: compounds 1 and 3 (each within the scatter of the next); then compounds 4 and 2 (each within the scatter of the next).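

In (this assay), chloro and methyl on this aromatic carbon, ortho to a carbamoyl group, cannot be told apart (a 2.0-fold lower number from compound 2 to compound 4 (0.30 log units; within the scatter)), so the poor result of compound 2 is no longer a finding about methyl alone. The two groups joined through oxygen both keep clearly lower numbers than chloro (a 5.8-fold higher number from compound 3 to compound 4 (0.76 log units; beyond the scatter); a 10-fold higher number from compound 1 to compound 4 (1.00 log units; beyond the scatter)), and this separation now rests on two small substituents rather than one, with no listed compound going against it. Nothing measured here explains this difference between the groups.

The compounds shown leave open whether the lower numbers go with the ether oxygen or with the ring carbons beyond it, a question that a methoxy group and a cyclobutyl group joined directly to the aromatic carbon could separate. They also leave open whether a cyclobutylamino group, or a longer chain ending in a carboxylic acid, would be tolerated on this carbon.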